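A few compounds are considered here, and "the series" means these few. Any claim that something is new, unique, unknown or untested is made for them only; others in the source may bear on it.

Measured so far in a functional assay on A549 cells (Homo sapiens) for inhibition, read by MTT assay, with a stated time of 72 h; a higher number here means a weaker inhibitor of growth, a lower number a stronger inhibitor of growth
- compound 1 `O=C1CC(N2C(=O)CSC2=S)C(=O)N1c1ccc(O)cc1` gives > 100000 nM (a limit)
- compound 2 `C=CCOc1ccccc1/C=C1\SC(=S)N(C2CC(=O)N(c3ccc(Cl)cc3)C2=O)C1=O` gives > 100000 nM (a limit)

For compound 2 the reading is a limit, > 100000 nM, and not a number. Its only companion in the series reads the same way, so the whole measured set sits on one line: the limit of > 100000 nM in this assay, at which 2 of the 2 values shown sit. Neither compound can therefore be ranked against the other.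

The next compound is compound 3 `C=CCOc1cccc(/C=C2\SC(=S)N(C3CC(=O)N(c4ccc(Cl)cc4)C3=O)C2=O)c1`, which has the same atoms as compound 2, joined differently. The change is 3-(allyloxy)phenyl in place of 2-(allyloxy)phenyl on a double-bonded chain carbon bound to a double-bonded ring carbon, with 3-(allyloxy)phenyl in place of 2-(allyloxy)phenyl on a double-bonded chain carbon bound to a double-bonded ring carbon.

For the measured compounds named here, no measured step is available to scale this change. No shift beyond the scatter is expected in this assay, and that expectation rests on compound 2 with its limit of > 100000 nM. The estimated move, in neither direction, is a number no higher from compound 2 to compound 3 (the limit leaves the size open). Another limit reading is the likeliest outcome. For compound 3 the expected value is 100000 nM, with an estimated range of 30000 nM to 300000 nM.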

Compound 3, concentration for 50% growth inhibition: > 100000 nM
Compound 3: a limit, no number; the forecaster's own chance of this, stated with the estimate: 70%; the middle value lies on the limit itself.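

With compound 2 and compound 3 both reading as limits rather than numbers, no step between them can be read, and the whole series sits on one line: the limit of > 100000 nM in this assay, at which 3 of the 3 values shown sit.

The compounds shown leave open whether any of them has a measurable growth-inhibition value, and how the three would rank against one another.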